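Notes on the Aryl Substituent Change to Compound 4

The source may report more compounds than this note shows. Statements on the series, on what has been measured and on what is new or still open speak of the compounds shown alone.

Measured compounds:
compound 1 `O=C(NC1CCCC1)c1noc(-c2ccc(Br)cc2)c1Br` — 410 nM
compound 2 `O=C(NC1CCCC1)c1noc(-c2ccccc2Cl)c1Br` — "not active" (no number reported)
compound 3 `O=C(NC1CCCC1)c1noc(-c2cccc(Cl)c2)c1Br` — 4220 nM

In a functional assay on CHO cells for antagonist activity at transient receptor potential cation channel subfamily V member 1 (Homo sapiens), read by fluorescence and calcium flux (a lower number here means a stronger inhibitor, a higher number a weaker inhibitor), compound 1 gives 410 nM, the lowest of the two numbers in hand. Compound 3 gives 4220 nM in this assay, and compound 2 is reported as not active without a number. Among the measured compounds shown here, the only measured step, a 10-fold higher number from compound 1 to compound 3 (1.01 log units; beyond the scatter), is large, and the missing number for compound 2 points the same way: changing the halogen on the aryl ring of the shared core is not neutral here.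

Compound 4 `O=C(NC1CCCC1)c1noc(-c2ccc(OC(F)(F)F)cc2)c1Br` differs from compound 1 by trifluoromethoxy in place of bromo on an aromatic carbon. For the measured compounds named here, no measured step exchanges one group for another on the same aromatic carbon, so the step from compound 1 to compound 3 bears only indirectly, showing that this assay responds strongly to the aryl substituent. With the substituent kept on the same carbon as in compound 1, the expectation for compound 4 is a step of a 1.3-fold higher number from compound 1 to compound 4 (0.13 log units; within the scatter) in this assay, small and near the scatter, in either direction. Compound 4 is therefore estimated at 550 nM, in the range 150 nM to 2500 nM.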

Compound 4, half-maximal inhibitory concentration: 1250 nM
Compound 4: the middle estimate sits 2.3-fold (0.36 log units) below what was measured; the range from low to high includes it.
By their numbers in this assay, from the lowest: compound 1; then compound 4; then compound 3.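

Trifluoromethoxy in place of bromo on the same aromatic carbon gives a 3.0-fold higher number from compound 1 to compound 4 (0.48 log units; beyond the scatter) in this assay, so the number at this position depends on the group it carries even when the carbon stays the same. The earlier step of a 10-fold higher number from compound 1 to compound 3 (1.01 log units; beyond the scatter) changed both the group and where it sits on the ring, whereas this one changes the group alone, and with 5 heavy atoms entering for 1 leaving, compound 4 still gives a measured number. No measured property of these compounds accounts for the rise in the number.

Going by these compounds, whether a methyl, a methoxy or an amine on this aromatic carbon would stay close to compound 1 remains open. So does whether a carboxylic acid here would give any measurable number at all.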